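The source may report more compounds than this note shows. Statements on the series, on what has been measured and on what is new or still open speak of the compounds shown alone.

Measured compounds:
- Compound 1 `COc1ccc(-c2cnc(NC(=O)c3ccc([N+](=O)[O-])cc3)n2C)cc1` gives in a toxicity assay on THP-1 cells (Homo sapiens) for inhibition (on this read-out higher numbers stand for lower toxicity in this test and lower numbers for higher toxicity in this test), only the assay limit > 100000 nM.
- Compound 2 `COc1ccc(-c2cnc(NC(=O)c3cccc(Br)c3)n2C)cc1` also reaches only the limit > 100000 nM in this assay.
- Compound 3 `COc1ccc(-c2cnc(NC(=O)c3ccccc3)n2C)cc1` likewise shows only the limit > 100000 nM in this assay.

Compound 3 therefore stands not at a measured number but at the ceiling of what this assay reports, and all three values sit there (the limit of > 100000 nM in this assay, at which 3 of the 3 values shown sit). The two steps that end at compound 3 cannot be sized: replacing nitro with hydrogen on an aromatic carbon gives a step that the two limits leave unreadable from compound 1 to compound 3, and replacing bromo with hydrogen on an aromatic carbon gives a step that the two limits leave unreadable from compound 2 to compound 3. Neither step, then, tells how strongly a change on the benzoyl part moves toxicity in this test.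

The unmeasured compound 4 `COc1ccc(-c2cnc(NC(=O)C3CCNCC3)n2C)cc1` makes a larger change on the same carbonyl carbon: piperidin-4-yl in place of phenyl on a carbonyl carbon. Among the measured compounds shown here, no measured step bears readably on this change, since every comparison available is capped by the limit. With nothing pointing toward a toxic effect, compound 4 is expected to behave like compound 3, and the expected step of a number no higher from compound 3 to compound 4 (the limit leaves the size open) is none beyond the scatter. Compound 4 is therefore estimated at 100000 nM, within a range from 50000 nM to 300000 nM, most likely again reported only as a limit.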

Compound 4, half-maximal cytotoxic concentration: > 100000 nM
Compound 4: only a limit was reported; the forecaster's own chance of this, stated with the estimate: 80%; the middle value sits exactly at the limit.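

Compound 4 also gives only a limit, so its steps from compound 2 and from compound 3 cannot be read, and the same holds for every comparison among these compounds: the limit of > 100000 nM in this assay, at which 4 of the 4 values shown sit.

The compounds shown leave open whether any of these groups on the carbonyl carbon differs from another in this assay.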